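Pyridin-2-yl to 6-methylpyridin-2-yl on compound 2

This account rests on a few compounds, and the source may have more. Where it says the series, first, only, none or still open, it means among the compounds named here.

In a functional assay on MCF7 cells (Homo sapiens) for cytotoxicity, with a stated time of 72 h (on this read-out lower numbers stand for stronger inhibition and higher numbers for weaker inhibition), compound 2 (`CC1(C)Cc2c(-c3ccncc3)c(-c3ccccn3)nn2C1`) stands at > 100000 nM as a limit of the assay, not a number. Compound 1 (`Cc1cccc(-c2nn3c(c2-c2ccncc2)C(CO)C(C)(C)C3)n1`), which already holds the 6-methylpyridin-2-yl group, gives > 100000 nM as a limit too. Compound 3 (`Cc1cccc(-c2nn3c(c2-c2ccncc2)CC(C)(C)C3)n1`) has methyl in place of hydrogen on an aromatic carbon, next to the ring nitrogen (methyl in place of hydrogen on an aromatic carbon). In this assay the expected a number no higher from compound 2 to compound 3 (the limit leaves the size open) stays within the scatter and has no direction, since compound 1 sits at the limit of > 100000 nM in this assay, at which 2 of the 2 values shown sit, with that same group. For compound 3 the estimated value is 100000 nM within an expected range of 30000 nM to 300000 nM and a limit reading is likely.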

Compound 3, half-maximal inhibitory concentration: > 100000 nM
Compound 3: only a limit was reported (the forecaster's own chance of this, stated with the estimate: 85%); the middle value sits exactly at the limit.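

Neither the step between compound 2 and compound 3 nor that between compound 1 and compound 3 can be read, because all three compounds sit at one limit: the limit of > 100000 nM in this assay, at which 3 of the 3 values shown sit.

On these data alone, whether methyl or hydroxymethyl changes the read-out at all stays open.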